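A few compounds are considered here, and "the series" means these few. Any claim that something is new, unique, unknown or untested is made for them only; others in the source may bear on it.

Measured in an ADME assay on microsomes from liver (Homo sapiens) for metabolic stability, read by LC-MS, using NADPH, tested at 1 uM; on this read-out higher numbers stand for a longer-lived compound and lower numbers for a shorter-lived compound:
- compound 1 `Cc1nc2c(N)ncnc2n1[C@@H]1O[C@H](CN(C)C/C=C\CNC(=O)OC(C)C)[C@@H](O)[C@H]1O` gives > 1.5 h (a limit)
- compound 2 `CN(C/C=C\CN)C[C@H]1O[C@@H](n2cnc3c(N)ncnc32)[C@@H]2OC(C)(C)O[C@@H]21` gives > 1.5 h (a limit)
- compound 3 `CNc1ncnc2c1ncn2[C@@H]1O[C@H](CN(C)C/C=C\CN)[C@H]2OC(C)(C)O[C@H]21` gives > 1.5 h (a limit)

Compound 3 stands at > 1.5 h, which is a limit and not a number. For the measured compounds named here, the series so far sits entirely at the limit of > 1.5 h in this assay, at which 3 of the 3 values shown sit, so no compound can be ranked against another in this assay.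

The next step leads to compound 4 `CCCCCCCCC(=O)Nc1ncnc2c1ncn2[C@@H]1O[C@H](CN(C)C/C=C\CN)[C@H]2OC(C)(C)O[C@H]21`, where octylcarbonyl takes the place of methyl on a nitrogen on an aromatic ring: octylcarbonyl in place of methyl on a nitrogen on an aromatic ring. The methylamino group thus becomes an (octylcarbonyl)amino group. Going by the values given here, the only measured step at this nitrogen is a step that the two limits leave unreadable from compound 2 to compound 3, and it offers no size to carry over. It also involves a much smaller change than the one now in view.

The expectation therefore rests on the size of the structural change alone, and it is a judgement with little support from measurement. A shorter half-life is expected, with the estimated change being an at least 1.5-fold lower number from compound 3 to compound 4 (0.17 log units; that floor lies within the scatter) and its size poorly defined. The estimate for compound 4 is 1 h with an expected range from 0.3 h to 3 h and a real chance that the expected outcome is only a limit.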

Compound 4, half-life: 0.162 h
Beside the measured number, compound 4's estimate is 6.2-fold (0.79 log units) above it; measured number outside the range, below it.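

In this assay, for the compounds shown here, the nitrogen on an aromatic ring is the first place where a change gives a readable shortening of half-life: octylcarbonyl in place of methyl gives a clear drop (an at least 9.2-fold lower number from compound 3 to compound 4 (0.96 log units; beyond the scatter)), and octylcarbonyl in place of hydrogen gives one of the same printed size (an at least 9.2-fold lower number from compound 2 to compound 4 (0.96 log units; beyond the scatter)). Both steps are floors, so the true drops may be larger, yet each already lies beyond the scatter, whereas the much smaller change of methyl in place of hydrogen at this nitrogen cannot be read. Going by these compounds alone, compound 4 is also the only compound here with a number rather than a limit, which gives the series its first fixed point on this read-out: the limit of > 1.5 h in this assay, at which 3 of the 4 values shown sit.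

As far as these compounds go, whether the shorter half-life follows the carbonyl or the length of the chain stays open, and an acetyl group or a plain octyl chain on this nitrogen would separate the two. From the compounds shown here alone, how far the half-lives of compound 2 and compound 3 extend past their limits also stays open, so the full size of both steps remains unknown.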